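This account rests on a few compounds, and the source may have more. Where it says the series, first, only, none or still open, it means among the compounds named here.

Measured compounds:
- compound 1, `CCCc1cc(N)c2cc(NC(=O)/C=C/c3ccc(C(C)(C)C)cc3)ccc2n1`: 22 nM
- compound 2, `CCCc1cc(N)c2cc(NC(=O)/C=C/c3ccc(O)cc3)ccc2n1`: 1100 nM
- compound 3, `CCCCc1ccc(/C=C/C(=O)Nc2ccc3nc(CCC)cc(N)c3c2)cc1`: 45 nM

In an assay on isolated protein for displacement of a labelled ligand from melanin-concentrating hormone receptor 1 (Homo sapiens) (a higher number here means a weaker inhibitor, a lower number a stronger inhibitor), compound 2 stands at the highest of the three numbers; its nearest neighbour is compound 3, and compound 1 is furthest from it. Compound 4, `CCCc1cc(N)c2cc(NC(=O)/C=C/c3ccc(Cl)cc3Cl)ccc2n1`, is not yet measured. It differs from compound 2 in one place: 2,4-dichlorophenyl in place of 4-hydroxyphenyl on a double-bonded chain carbon bound to a double-bonded chain carbon.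

Among the compounds with values here, two measured steps bear on this change, both of which exchange the hydroxy group on the aromatic carbon for a group without a donor or acceptor. From compound 1 to compound 2 the step was a 50-fold higher number from compound 1 to compound 2 (1.70 log units; beyond the scatter), and from compound 2 to compound 3 it was a 24-fold lower number from compound 2 to compound 3 (1.39 log units; beyond the scatter). Both steps are large and point the same way: removing the hydroxy lowers the number substantially. The change to compound 4 also removes the hydroxy, and the entering group carries no donor or acceptor, so a large drop in the number is expected in this assay, of a size comparable to those two steps. Compound 4 is therefore estimated at 50 nM, with a range of 15 nM to 200 nM, corresponding to an expected step of a 22-fold lower number from compound 2 to compound 4 (1.34 log units; beyond the scatter).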

Compound 4, half-maximal inhibitory concentration: 6.6 nM
Compound 4: middle estimate off by 7.6-fold (0.88 log units), on the high side; the whole stated range lies above it.
By their numbers in this assay, from the lowest: compound 4; then compound 1; then compound 3; then compound 2.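

In this assay, within the data shown here, exchanging 4-hydroxyphenyl for 2,4-dichlorophenyl gives a 170-fold lower number from compound 2 to compound 4 (2.22 log units; beyond the scatter), a step larger in printed size than a 24-fold lower number from compound 2 to compound 3 (1.39 log units; beyond the scatter), so the earlier steps did not mark how far a change at this place can reach. A low number here also needs no alkyl group on the ring: compound 4, with two chlorine atoms, gives 6.6 nM, while compound 1, the lowest before it, gives 22 nM. Nothing available explains the size of this step.

The step removes the hydroxy group and brings in both chlorine atoms at once, so the compounds shown cannot divide it between those parts, and a phenyl ring carrying a single chlorine would be needed to do so. Going by these compounds, how bromine, methoxy or a carboxylic acid would fare on this ring also stays open.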